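This account rests on a few compounds, and the source may have more. Where it says the series, first, only, none or still open, it means among the compounds named here.

The series shares one core, shown in compound 3 `Cc1nc(Nc2ccccc2)sc1C(=O)/C=C/c1ccccc1`, and the compounds differ in what sits on the phenyl group and on the second aromatic ring. In a functional assay on NCI-H460 cells (Homo sapiens) for cytotoxicity, read by MTT assay (on this read-out higher numbers stand for weaker inhibition and lower numbers for stronger inhibition), compound 3 gives only a limit of the assay, > 25000 nM. Compound 1 `COc1cccc(/C=C/C(=O)c2sc(Nc3ccccc3)nc2C)c1` carries a methoxy group on an aromatic carbon of the phenyl group; in this assay compound 1 also gives only a limit, > 25000 nM. Compound 2 `Cc1cccc(Nc2nc(C)c(C(=O)/C=C/c3ccccc3Cl)s2)c1`, which has a 2-chlorophenyl group together with a methyl on the other aromatic ring, likewise gives only a limit in this assay, > 25000 nM. Within the data shown here, the single step that can be traced between measured compounds, a step that the two limits leave unreadable from compound 1 to compound 3, has no readable size, because of the limit of > 25000 nM in this assay, at which 3 of the 3 values shown sit.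

Compound 4 `Cc1nc(Nc2ccccc2)sc1C(=O)/C=C/c1ccccc1Cl` is derived from compound 3 by chloro in place of hydrogen on an aromatic carbon. Among the measured compounds shown here, no measured step bears directly on this change; the nearest information is that compound 2, which already carries the 2-chlorophenyl group, sits at the limit as well. With every measured value at the limit, the step from compound 3 to compound 4 is expected to be a step that the limit leaves unreadable from compound 3 to compound 4, that is, nothing beyond the scatter. Compound 4 is therefore expected to give about 40000 nM in this assay, within a range from 15000 nM to 120000 nM, and most likely the result will again be reported only as a limit.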

Compound 4, half-maximal inhibitory concentration: > 25000 nM
Compound 4: a limit, no number; the forecaster's own chance of this, stated with the estimate: 85%; the middle value does not contradict the limit.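

No step from compound 1, compound 2 or compound 3 to compound 4 can be read in this assay, because all four compounds end at the same limit: the limit of > 25000 nM in this assay, at which 4 of the 4 values shown sit.

The compounds shown leave open whether any change on the phenyl group or the second aromatic ring can bring the shared core to a measurable value.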